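The compounds below may be only part of what the source reports. "The series", "measured", "known", "first", "only" and "open" are said of these compounds alone.

Compound 3 `c1ccc2c(c1)CN[C@@H](CN(CCCCNC1CCSCC1)[C@H]1CCCc3cccnc31)C2` carries a thian-4-yl group on the distal amine and gives 54.7 nM in a functional assay on cells for antagonist activity at C-X-C chemokine receptor type 4 (Homo sapiens), read by fluorescence and calcium flux, with stated times of 25 min and 90 s (on this read-out lower numbers stand for stronger inhibition and higher numbers for weaker inhibition), the second highest number among three compounds; compound 2 `c1ccc2c(c1)CN[C@@H](CN(CCCCNC1CCCCC1)[C@H]1CCCc3cccnc31)C2` with cyclohexyl gives 75.2 nM, and compound 1 `c1ccc(CNCCCCN(C[C@H]2Cc3ccccc3CN2)[C@H]2CCCc3cccnc32)cc1` with benzyl gives 20.1 nM. The benzyl compound stands apart, since a 3.7-fold higher number from compound 1 to compound 2 (0.57 log units; beyond the scatter) and a 2.7-fold higher number from compound 1 to compound 3 (0.43 log units; beyond the scatter), whereas a 1.4-fold lower number from compound 2 to compound 3 (0.14 log units; within the scatter). Compound 4 `NCc1ccccc1CN(C[C@H]1Cc2ccccc2CN1)[C@H]1CCCc2cccnc21` is reached from compound 3 by a group of 8 heavy atoms (7 carbon, 1 nitrogen; one six-membered aromatic ring of carbon only) in place of a group of 10 heavy atoms (8 carbon, 1 nitrogen, 1 sulfur; one six-membered non-aromatic ring with 1 hetero atom), on a saturated chain carbon bound to an amine nitrogen. The step of a 2.7-fold higher number from compound 1 to compound 3 (0.43 log units; beyond the scatter) is the one that bears most directly on this change, as compound 4 again places an aromatic ring on the carbon bound to the amine nitrogen, although the chain is shortened and the aminomethyl group is new, so the exchange is not a simple reversal. A modest lowering of the number is therefore expected, roughly the size of the benzyl-to-thianyl step, such that compound 4 is estimated to give 28 nM with a range from 9 nM to 90 nM, meaning a 2.0-fold lower number from compound 3 to compound 4 (0.29 log units; within the scatter).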

Compound 4, half-maximal inhibitory concentration in the C-X-C chemokine receptor type 4 assay: 50.8 nM
Compound 4: the middle estimate sits 1.8-fold (0.26 log units) below what was measured, within the range that was stated.
By their numbers in the C-X-C chemokine receptor type 4 assay, from the lowest: compound 1; then compounds 4, 3 and 2 (each within the scatter of the next).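

In the C-X-C chemokine receptor type 4 assay this position takes very different groups with little consequence, since a 1.1-fold lower number from compound 3 to compound 4 (0.03 log units; within the scatter) and a 1.5-fold lower number from compound 2 to compound 4 (0.17 log units; within the scatter), while the benzyl-bearing chain keeps its separate standing, with a 2.5-fold higher number from compound 1 to compound 4 (0.40 log units; beyond the scatter). The 2-(aminomethyl)phenyl group therefore serves on the saturated chain carbon bound to an amine nitrogen without a thian-4-yl or cyclohexyl amine at the end of a chain. In a physicochemical assay for permeability, using PAMPA, with a stated time of 4 h, at pH 7.4, tested at 100 uM (on this read-out lower numbers stand for lower permeability and higher numbers for higher permeability), compound 3 gives 2 nm/s and compound 4 gives 214 nm/s. What the earlier compounds could not show is that a change with so little effect on inhibition can still separate a pair widely in the physicochemical assay: the measured apparent permeability of compound 3, 2 nm/s, and of compound 4, 214 nm/s, a 110-fold higher number (2.03 log units; beyond the scatter)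

Open, as far as these compounds go, is whether the aminomethyl group matters at all, or whether a plain phenyl or a hydroxymethyl-substituted phenyl would serve equally at this position. Also open, from the compounds shown here alone, is whether any group here can combine the inhibition of the benzyl-bearing chain with high apparent permeability.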